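Series notes: fluoro for methyl on the aryl ring

The source may hold more compounds than are shown below. What is called first, only, known or untested is meant among the compounds shown, and "the series" means these compounds.

Three compounds of the shared core have been prepared so far. Compound 1 `Cc1nc(-c2ccc(Cl)s2)sc1COc1ccc2c(c1)OCC2CC(=O)O` has no result reported in a functional assay on CHO cells for agonist activity at Free fatty acid receptor 1 (Homo sapiens), read by FLIPR and calcium flux; on this read-out lower numbers stand for an effect already at smaller amounts and higher numbers for an effect only at larger amounts of compound: the entry for compound 1 reads "not determined" (no result reported). Compound 2 `Cc1ccccc1-c1nc(C)c(COc2ccc3c(c2)OCC3CC(=O)O)s1` likewise has no result in this assay: the entry for compound 2 reads "not determined" (no result reported). For the measured compounds named here, compound 3 `Cc1cccc(-c2nc(C)c(COc3ccc4c(c3)OCC4CC(=O)O)s2)c1` is the only member with a number: in this assay compound 3 gives 119 nM. Going by the values given here, with no second measured value in the set, no step between measured compounds can be stated, and compound 3 stands alone as the reference point.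

Compound 4 `Cc1nc(-c2cccc(F)c2)sc1COc1ccc2c(c1)OCC2CC(=O)O` differs from compound 3 in one place (fluoro in place of methyl on an aromatic carbon). The group that leaves and the group that enters are each a single heavy atom, neither carries a donor or an acceptor, and the place on the six-membered aromatic ring of carbon only, meta to a large group, is unchanged. Nothing in the measured set speaks to what such an exchange does in this assay, so no direction can be read from the data.

The expectation is therefore a step from compound 3 to compound 4 of a 1.3-fold higher number from compound 3 to compound 4 (0.10 log units; within the scatter) in this assay, within the usual scatter rather than beyond it. Compound 4 is estimated at 150 nM in this assay, with a range from 55 nM to 420 nM.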

Compound 4, half-maximal effective concentration: 64.8 nM
Compound 4: middle estimate off by 2.3-fold (0.36 log units), on the high side; the measured number falls inside the stated range.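

In this assay the set now holds its first readable step: fluoro in place of methyl on an aromatic carbon, meta to a large group, gives a 1.8-fold lower number from compound 3 to compound 4 (0.26 log units; within the scatter). Since that step stays within the scatter, 3-methylphenyl and 3-fluorophenyl cannot be told apart on this read-out, so at this place on the aromatic ring a single fluorine serves as well as a methyl, and the number stays in the same range for both groups, which a lone value for compound 3 could not show. No measurement of any property of these compounds accompanies the result, so the data offer nothing that would account for it.

On these data alone, compounds 1 and 2 carry no number, so steps involving them cannot be read, and the effect of the 5-chlorothiophene-type exchange in compound 1 or of moving the methyl in compound 2 stays open. Also open, as far as these compounds go, is whether a larger or different group at this same place, such as trifluoromethyl, a nitrile or an amine, would move the number beyond the scatter, or whether the range seen for methyl and fluoro holds there too.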